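Methylselenyl analogue of the benzylselenyl imide series

The source may hold more compounds than are shown below. What is called first, only, known or untested is meant among the compounds shown, and "the series" means these compounds.

Compound 3 `O=C(/N=C(/NC(=O)c1ccno1)[Se]Cc1ccccc1)c1ccno1` gives 9120 nM in a functional assay on HepG2 cells (Homo sapiens) for cytotoxicity, read by MTT assay, with a stated time of 72 h (a lower number here means a stronger inhibitor of growth, a higher number a weaker inhibitor of growth), and holds the lowest of the two numbers in hand. Compound 1 `CS/C(=N\C(=O)c1sccc1Cl)NC(=O)c1sccc1Cl` gives 65300 nM. For compound 2 `CS/C(=N\C(=O)c1ccno1)NC(=O)c1ccno1` the result is only a limit, > 100000 nM. Here the limit of > 100000 nM in this assay, at which 1 of the 3 values shown sits, marks the edge of what this assay reports. Compound 4 `C[Se]/C(=N\C(=O)c1ccno1)NC(=O)c1ccno1` differs from compound 3 by hydrogen in place of phenyl on a saturated chain carbon bound to a selenium atom. Among the measured compounds shown here, the one measured step touching this site is an at least 10-fold lower number from compound 2 to compound 3 (1.04 log units; beyond the scatter), in which the benzyl group and the selenium entered together, so their separate shares cannot be read. Taking away only the phenyl is expected to return part of that step, a rise in the number, but not all of it. For compound 4 the estimate is 30000 nM, with a range of 8000 nM to 110000 nM, a step of a 3.3-fold higher number from compound 3 to compound 4 (0.52 log units; beyond the scatter).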

Compound 4, concentration for 50% growth inhibition: 510 nM
Estimate against measurement, compound 4: 59-fold (1.77 log units) above; measured number below the stated range.
By their numbers in this assay, from the lowest: compound 4; then compound 3; then compound 1. At a limit, above all of these: compound 2.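

In this assay, hydrogen in place of phenyl on a saturated chain carbon bound to a selenium atom gives an 18-fold lower number from compound 3 to compound 4 (1.25 log units; beyond the scatter), so the phenyl is not needed for growth inhibition in this pair. With methyl kept, selenium in place of sulfur gives an at least 190-fold lower number from compound 2 to compound 4 (2.29 log units; beyond the scatter), which reads the selenium apart from the benzyl group. Compound 2 stands at a limit, not a number, so the true size of that step stays open: the limit of > 100000 nM in this assay, at which 1 of the 4 values shown sits.

Going by these compounds, whether an ethyl group or a longer chain on selenium keeps the low number stays open. So does whether selenium in place of sulfur gives a similar step on the core of compound 1.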